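This account rests on a few compounds, and the source may have more. Where it says the series, first, only, none or still open, it means among the compounds named here.

In a functional assay on HUVEC cells (Homo sapiens) for inhibition, with a stated time of 4 days (a lower number here means a stronger inhibitor, a higher number a weaker inhibitor), compound 1 `COc1ccc(C(N)=O)cc1/C=C/c1ccc(Cl)cc1` gives 87 nM and compound 2 `CNC(=O)c1ccc(OC)c(/C=C/c2ccc(Cl)cc2)c1` gives 190 nM as the higher of the two numbers, which makes compound 2 the weaker inhibitor of this pair. Still unmeasured is compound 3 `COc1ccc(C(=O)N(C)C)cc1/C=C/c1ccc(Cl)cc1` and it differs from compound 2 by a single edit: methyl in place of hydrogen on an amide-type nitrogen, so that methylcarbamoyl becomes dimethylcarbamoyl. Among the measured compounds shown here, only one measured step bears on this change, the same edit made once before. For the measured compounds named here, that step was modest, and resting on a 2.2-fold higher number from compound 1 to compound 2 (0.34 log units; beyond the scatter) as the only precedent, a step of similar size toward a higher number is expected in this assay for compound 3. One step is thin evidence, and the data do not show whether a second methyl will act as the first did. Compound 3 also has no amide hydrogen left, unlike compound 1 and compound 2, so the precedent is only a rough guide. The estimated step is a 2.1-fold higher number from compound 2 to compound 3 (0.32 log units; beyond the scatter) with room on either side. For compound 3 the estimated value is 400 nM with an expected range from 170 nM to 1200 nM for now.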

Compound 3, half-maximal inhibitory concentration: 2500 nM
Compound 3: the middle estimate sits 6.3-fold (0.80 log units) below what was measured; measured number outside the range, above it.
By their numbers in this assay, from the lowest: compound 1; then compound 2; then compound 3.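

In this assay, the second methyl on the amide-type nitrogen has a far larger effect than the first: a 13-fold higher number from compound 2 to compound 3 (1.12 log units; beyond the scatter), set against a 2.2-fold higher number from compound 1 to compound 2 (0.34 log units; beyond the scatter), so the same edit at this nitrogen does not give a similar step each time. Taken as one change, dimethylamino in place of amino on the carbonyl carbon gives a 29-fold higher number from compound 1 to compound 3 (1.46 log units; beyond the scatter), and compound 3 is also the only one of the three with no amide hydrogen left, which fits the sharp rise in the number without proving that the missing hydrogen is what matters. No supporting measurement is available to explain why the second methyl has so much more effect than the first.

The compounds shown leave open whether the large step follows from losing the amide hydrogen or from the added methyl itself. An ethyl group on the amide nitrogen, which would keep the amide hydrogen, could help separate the two, while a carboxylic acid in place of the whole carbamoyl group would show how much this position depends on an amide at all.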